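Amide series: replacing bromo on compound 3

This account rests on a few compounds, and the source may have more. Where it says the series, first, only, none or still open, it means among the compounds named here.

The shared core carries a three-carbon amide chain, and the substituent on the amide nitrogen is what varies. Compound 1 `CC(C)(C)NC(=O)CCc1cccc2c1B(O)OC2` reaches only a limit in a functional assay on SK-OV-3 cells (Homo sapiens) for antiproliferative activity, read by MTT assay, with a stated time of 72 h (on this read-out lower numbers stand for stronger inhibition and higher numbers for weaker inhibition), namely > 100000 nM. That limit, (the limit of > 100000 nM in this assay, at which 1 of the 3 values shown sits), is one of the three values here. Compound 2 `O=C(CCc1cccc2c1B(O)OC2)Nc1ccc(I)cc1` gives 51000 nM in this assay. Compound 3 `O=C(CCc1cccc2c1B(O)OC2)Nc1cccc(Br)c1` gives 540 nM in this assay, the lowest of the two numbers, with compound 2 nearest after the step of a 94-fold lower number from compound 2 to compound 3 (1.98 log units; beyond the scatter). The step of an at least 180-fold lower number from compound 1 to compound 3 (2.26 log units; beyond the scatter) is large and beyond the scatter, whereas the step of an at least 1.9-fold lower number from compound 1 to compound 2 (0.29 log units; that floor lies within the scatter) stays at a floor inside the scatter.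

Compound 4 `CSc1cccc(-c2cccc(NC(=O)CCc3cccc4c3B(O)OC4)c2)c1` differs from compound 3 by 3-(methylsulfanyl)phenyl in place of bromo on an aromatic carbon. Going by the values given here, no measured step exchanges a halogen for an aromatic ring on the nitrogen substituent, so none bears directly on this change; the measured steps only show that the aryl amide of compound 3 stands far below compound 2 and compound 1. The expectation therefore rests on compound 3 alone and carries a wide range. Compound 4 is estimated at 800 nM in this assay, between 100 nM and 8000 nM. The expected step of a 1.5-fold higher number from compound 3 to compound 4 (0.17 log units; within the scatter) lies within the scatter.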

Compound 4, half-maximal inhibitory concentration: 150 nM
Compound 4: the middle estimate sits 5.3-fold (0.73 log units) above what was measured, and the stated range covers the measured number.
By their numbers in this assay, from the lowest: compound 4; then compound 3; then compound 2. At a limit, above all of these: compound 1.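

Going by these compounds alone, compound 4 gives the first step that keeps the aryl amide and changes only the group on its aromatic ring, at an aromatic carbon meta to a large group; the earlier steps changed only the whole substituent on the amide nitrogen. In this assay the exchange of bromo, a single heavy atom, for 3-(methylsulfanyl)phenyl, with eight heavy atoms and one six-membered aromatic ring, gives a 3.6-fold lower number from compound 3 to compound 4 (0.56 log units; beyond the scatter) and so this position accepts a far larger group with a modest gain rather than a loss. Nothing measured here gives a reason for this step.

Going by these compounds, whether the step belongs to the added phenyl ring itself or to the methylsulfanyl group it carries remains open, and a plain phenyl at this position would separate the two. Also open, on these data alone, is how the number responds to other groups on that added ring, such as an amine or a carboxylic acid in place of methylsulfanyl, and whether the same step holds with a longer chain between the shared core and the amide.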